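This account rests on a few compounds, and the source may have more. Where it says the series, first, only, none or still open, it means among the compounds named here.

Going by the values given here, in an ADME assay on Vero 76 cells (Chlorocebus sabaeus) for cytotoxicity, read by microscopy (a lower number here means that less compound is tolerated, a higher number that more compound is tolerated), compound 1 `CC(C)[C@@H](Nc1nc(Cl)nc2c1ncn2[C@H]1[C@H](O)[C@H](O)[C@]2(CCl)C[C@H]12)C1CC1` gives 32000 nM, the only true number in the set. Compound 2 `CC(C)C(Nc1nc(Cl)nc2c1ncn2[C@H]1[C@H](O)[C@H](O)[C@]2(CO)C[C@H]12)C(C)C` reads > 100000 nM, which is a limit and not a number. As far as these compounds go, compound 3 `O[C@@H]1[C@H](O)[C@@H]2C[C@@H]2[C@H]1n1cnc2c(NCC(C3CC3)C3CC3)nc(Cl)nc21` reads > 50000 nM, which is also a limit and not a number, so its exact standing stays open. Compound 4 `O[C@@H]1[C@H](O)[C@@H]2C[C@@H]2[C@H]1n1cnc2c(NC(C3CCC3)C3CCC3)nc(Cl)nc21` carries dicyclobutylmethyl in place of 2,2-dicyclopropylethyl on a nitrogen on an aromatic ring. Among the compounds with values here, no measured pair shows a step of this kind, so the expectation is weakly anchored, and compound 1 at 32000 nM marks the only measured number. Expected is a number no higher from compound 3 to compound 4 (the limit leaves the size open), nothing beyond the scatter in either direction. Compound 4 is estimated at 50000 nM, with an expected range from 20000 nM to 100000 nM.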

Compound 4, half-maximal cytotoxic concentration: 16000 nM
For compound 4 the middle estimate is 3.1-fold (0.49 log units) above the measured one, and the stated range ends above it.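

In this assay, going by these compounds alone, dicyclobutylmethyl in place of 2,2-dicyclopropylethyl on a nitrogen on an aromatic ring gives an at least 3.1-fold lower number from compound 3 to compound 4 (0.49 log units; beyond the scatter), the first readable step at this position, and it points towards less compound being tolerated. The size of the step is open-ended because compound 3 reads only as a limit: the limit of > 50000 nM in this assay, at which 1 of the 4 values shown sits.

The compounds shown do not separate the change in ring size from the change in how the rings are attached to the nitrogen. As far as these compounds go, how a group bearing an amine or a carboxylic acid at this position would read also stays open.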